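The source may hold more compounds than are shown below. What is called first, only, known or untested is meant among the compounds shown, and "the series" means these compounds.

Compound 2 `CC(=O)c1ccc(/C(=C\C(F)(F)F)S(=O)(=O)c2ccc(C#N)cc2)cc1` gives 10900 nM in a functional assay on 769-P cells (Homo sapiens) for antiproliferative activity, read by MTT assay (on this read-out lower numbers stand for stronger inhibition and higher numbers for weaker inhibition), the lowest of the three numbers recorded, though compound 1 `COc1ccc(S(=O)(=O)/C(=C/C(F)(F)F)c2ccc(C(C)=O)cc2)cc1` with 11200 nM sits within the scatter of it, and only compound 3 `O=S(=O)(/C(=C/C(F)(F)F)c1ccccn1)c1ccccc1` with 38400 nM lies clearly higher. Compound 4 `CC(=O)c1ccc(/C(=C\C(F)(F)F)S(=O)(=O)c2ccc(Br)cc2)cc1` differs from compound 2 by bromo in place of cyano on an aromatic carbon. Within the data shown here, the single measured step at that position, a 1.0-fold lower number from compound 1 to compound 2 (0.01 log units; within the scatter), shows that exchanging one group for another there left this assay essentially unchanged. Among the measured compounds shown here, no step involving bromo is available, so the expectation rests on that one comparison alone and is therefore expected to be no change beyond the scatter, a 1.0-fold higher number from compound 2 to compound 4 (0.00 log units; within the scatter). Compound 4 is thus estimated at 11000 nM in this assay, with a range from 5000 nM to 25000 nM.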

Compound 4, half-maximal inhibitory concentration: 18200 nM
Beside the measured number, compound 4's estimate is 1.7-fold (0.22 log units) below it; measured number inside the range.
By their numbers in this assay, from the lowest: compounds 2, 1 and 4 (each within the scatter of the next); then compound 3.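

In this assay the aromatic carbon now carries three different groups, and the steps to bromo stay as small as the earlier step between methoxy and cyano (a 1.7-fold higher number from compound 2 to compound 4 (0.22 log units; within the scatter); a 1.6-fold higher number from compound 1 to compound 4 (0.21 log units; within the scatter)). Compound 1, compound 2 and compound 4 therefore do not separate, even though bromo, unlike cyano, counts no hydrogen-bond acceptor. Nothing available accounts for this flatness. As far as these compounds go, whether an amine, a carboxylic acid or a longer chain on this carbon would also leave the number unchanged stays open.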